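Side-chain variation and myeloperoxidase inhibition

A few compounds are considered here, and "the series" means these few. Any claim that something is new, unique, unknown or untested is made for them only; others in the source may bear on it.

compound 1 `CCCc1c[nH]c2ccc(F)cc12`: > 100 nM
compound 2 `NC(=O)CCCCc1c[nH]c2ccc(F)cc12`: 39 nM
compound 3 `NCCCCc1c[nH]c2ccc(C(=O)O)cc12`: "not active" (no number reported)

For the measured compounds named here, in an assay on isolated protein (urine) for inhibition of Myeloperoxidase (Homo sapiens), with a stated time of 5 min (a lower number here means a stronger inhibitor, a higher number a weaker inhibitor), compound 2 gives 39 nM, the only single number among the three results. For compound 1 the result is > 100 nM, which is a limit of the assay. Compound 3 is reported as "not active" (no number reported). Going by the values given here, the one step between measured compounds that differ in a single place is an at least 2.5-fold lower number from compound 1 to compound 2 (0.40 log units; beyond the scatter), with compound 1 sitting at the limit of > 100 nM in this assay, at which 1 of the 3 values shown sits.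

Compound 4 `NCC(N)CCc1c[nH]c2ccc(F)cc12` has not been measured in this assay. It differs from compound 2 as 1,2-diaminoethyl in place of 2-carbamoylethyl on a saturated chain carbon, two bonds along the chain from an aromatic carbon. Among the compounds with values here, no measured step bears directly on this exchange: the step from compound 1 to compound 2 adds a carbamoyl group to a chain, whereas here the amide-bearing chain leaves and a shorter diamine chain enters. Compound 3 also carries a primary amine on its chain and is inactive, but it differs from compound 2 in the core as well, so its value offers only a weak pointer. The step is therefore expected to be a 3.8-fold higher number from compound 2 to compound 4 (0.59 log units; beyond the scatter), toward a weaker inhibitor, with wide uncertainty. Compound 4 is estimated at 150 nM, with a range from 30 nM to 800 nM.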

Compound 4, half-maximal inhibitory concentration: 60 nM
For compound 4 the middle estimate is 2.5-fold (0.40 log units) above the measured one, within the range that was stated.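

In this assay, exchanging 2-carbamoylethyl for 1,2-diaminoethyl on a saturated chain carbon, two bonds along the chain from an aromatic carbon, gives a 1.5-fold higher number from compound 2 to compound 4 (0.19 log units; within the scatter), so the two chains cannot be told apart in this read-out. For the compounds shown here, compound 4 carries no carbonyl, which shows that on the shared core a chain without the amide can match compound 2 within the scatter, something the earlier compounds did not show. The second new step is less informative: an at least 1.6-fold lower number from compound 1 to compound 4 (0.22 log units; that floor lies within the scatter), with its starting value a limit and not a number: the limit of > 100 nM in this assay, at which 1 of the 4 values shown sits.

From the compounds shown here alone, it remains open whether one of the two amines of 1,2-diaminoethyl alone accounts for the value of compound 4, or whether a hydroxyl group or a carboxylic acid at this place on the chain would give a value of the same order. Compound 3 also carries an amine on its chain but differs from compound 4 in more than one place, so the role of the core substituent in its "not active" result stays unresolved.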